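The source may hold more compounds than are shown below. What is called first, only, known or untested is meant among the compounds shown, and "the series" means these compounds.

Compound 1 `Fc1ccccc1Cc1nc(-c2nc(C(F)(F)F)n[nH]2)n2ccccc12` is the starting point. Going by the values given here, in an in vitro ADME assay on microsomes from liver (Homo sapiens) for metabolic stability (a lower number here means slower removal, a higher number faster removal of the compound), compound 1 gives 72 mL.min-1.g-1, the only plain number among the three measured compounds. Compound 2 `Fc1ncncc1Cn1nc(-c2nc(C(F)(F)F)n[nH]2)c2cccnc21` is reported in this assay as the limit < 11 mL.min-1.g-1. Compound 3 `Cc1ncc(Cn2nc(-c3nc(C(F)(F)F)n[nH]3)c3cccnc32)cn1` is likewise reported in this assay as the limit < 7 mL.min-1.g-1. Going by these compounds, the step that the two limits leave unreadable from compound 2 to compound 3 cannot be read because the limit of < 11 mL.min-1.g-1 in this assay, at which 1 of the 3 values shown sits, and the limit of < 7 mL.min-1.g-1 in this assay, at which 1 of the 3 values shown sits, are both limits, so its size stays unknown.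

Compound 4 `Fc1ccccc1Cc1nc(-c2nc(C(F)F)n[nH]2)n2ccccc12` differs from compound 1 in one place: hydrogen in place of fluoro on a saturated chain carbon bound to an aromatic carbon and two fluorine atoms. Among the compounds with values here, no measured step touches this change; the single step recorded concerns a different group and is in any case unreadable. With no measured guide, the step expected in this assay is a 1.1-fold lower number from compound 1 to compound 4 (0.04 log units; within the scatter), that is, none beyond the scatter, with a wide margin of doubt. Compound 4 is therefore expected to give 65 mL.min-1.g-1 in this assay, within a range from 25 mL.min-1.g-1 to 160 mL.min-1.g-1.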

Compound 4, intrinsic clearance in microsomes: 62 mL.min-1.g-1
The estimate for compound 4 lay 1.0-fold (0.02 log units) above the measured number; measured number inside the range.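

Replacing one fluoro with hydrogen on the saturated chain carbon, which turns trifluoromethyl into difluoromethyl, gives in this assay a 1.2-fold lower number from compound 1 to compound 4 (0.06 log units; within the scatter), so at this position the swap does not separate the two compounds. Going by these compounds alone, this is the first step that can be read, as the only earlier step joins two limits and its size stays unknown. Nothing shown points to a cause for this result.

Still open, going by these compounds, is whether a different group at this place, such as a methyl, a longer chain or an amine, would move the number beyond the scatter. Also open, on these data alone, is whether trifluoromethyl to difluoromethyl would give a similar result on the core of compound 2, which differs from the core of compound 1.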